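The source may hold more compounds than are shown below. What is called first, only, known or untested is meant among the compounds shown, and "the series" means these compounds.

Compound 1 `CCc1cc(C(O)Cc2ccccc2)c2cn[nH]c2c1`: 18%
Compound 2 `OC(Cc1ccccc1)c1cc(-c2ccccc2)cc2[nH]ncc12`: 14%

In an assay for inhibition of Indoleamine 2,3-dioxygenase 1 variant C129Y (Homo sapiens), read by spectrophotometry, with a stated time of 30 min, tested at 10 uM (on this read-out higher numbers stand for more inhibition at the one concentration tested (going by the name of the read-out) and lower numbers for less inhibition), compound 2 gives 14%. Compound 1 gives 18%, and the step of a number 4 percentage points lower from compound 1 to compound 2 (within the scatter) is within the scatter, so the two compounds stand together. Compound 3 `OC(Cc1ccccc1)c1cc(C2CC2)cc2[nH]ncc12` differs from compound 2 by cyclopropyl in place of phenyl on an aromatic carbon. For the measured compounds named here, only one measured step bears on this place, a number 4 percentage points lower from compound 1 to compound 2 (within the scatter), which set phenyl in place of ethyl on an aromatic carbon without moving beyond the scatter. Going by the values given here, no measured step exchanges phenyl for cyclopropyl. Compound 3 is therefore expected to change by a number 1 percentage points higher from compound 2 to compound 3 (within the scatter), nothing beyond the scatter. Compound 3 is estimated at 15%, between 0% and 35%.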

Compound 3, a percentage reported as inhibition, at one concentration (the size of the read-out at that concentration, not a potency): 20%
The estimate for compound 3 lay 5 percentage points below the measured number; measured number inside the range.
By their numbers in this assay, from the lowest: compounds 2, 1 and 3 (each within the scatter of the next).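

In this assay the change to cyclopropyl gives a number 6 percentage points higher from compound 2 to compound 3 (within the scatter) and also a number 2 percentage points higher from compound 1 to compound 3 (within the scatter) on the shared core. A small non-aromatic ring at this aromatic carbon therefore stands together with phenyl and ethyl, and the three compounds cannot be told apart here. Nothing available explains this result. Still open, on these data alone, is whether an amine, a carboxylic acid or a longer chain at this position would move the number beyond the scatter. Changes elsewhere on the core, such as at the hydroxyl group, also remain untested in these three compounds.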